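Solubility across aryl replacements on the shared core

The compounds below may be only part of what the source reports. "The series", "measured", "known", "first", "only" and "open" are said of these compounds alone.

Compound 1 `Cc1cc(NCc2ccccn2)n2ncc(Br)c2n1` carries bromo on an aromatic carbon of the shared core; in a physicochemical assay for solubility, read by HPLC, using the shake flask method, measured as kinetic solubility, with a stated time of 2 h, at pH 7.4 (on this read-out higher numbers stand for higher solubility and lower numbers for lower solubility), compound 1 gives 89300 nM. Compound 2 `Cc1cc(NCc2ccccn2)n2ncc(-c3cccc(Cl)c3)c2n1` bears 3-chlorophenyl at that carbon. In this assay compound 2 reaches only a limit of the assay, < 5000 nM; this is the limit of < 5000 nM in this assay, at which 1 of the 3 values shown sits. Compound 3 `Cc1cc(NCc2ccccn2)n2ncc(-c3ccsc3)c2n1` bears thiophen-3-yl there, and in this assay compound 3 gives 9000 nM. Of the two numbers proper the lower is that of compound 3, the gap to the other being a 9.9-fold lower number from compound 1 to compound 3 (1.00 log units; beyond the scatter). The other replacement of bromo is an at least 17-fold lower number from compound 1 to compound 2 (1.25 log units; beyond the scatter), and the exchange of one aryl for another is an at least 1.8-fold higher number from compound 2 to compound 3 (0.25 log units; that floor lies within the scatter).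

Compound 4 `Cc1cc(NCc2ccccn2)n2ncc(-c3ccc(O)cc3)c2n1` is not yet measured. It differs from compound 3 by 4-hydroxyphenyl in place of thiophen-3-yl on an aromatic carbon. Within the data shown here, the steps that bear on it are the two aryl replacements of bromo, a 9.9-fold lower number from compound 1 to compound 3 (1.00 log units; beyond the scatter) modest and an at least 17-fold lower number from compound 1 to compound 2 (1.25 log units; beyond the scatter) large, and the aryl-for-aryl exchange, an at least 1.8-fold higher number from compound 2 to compound 3 (0.25 log units; that floor lies within the scatter), which lay within the scatter. Among the measured compounds shown here, compound 4 brings a hydrogen-bond donor that no measured compound carries, so the aryl-for-aryl exchange is the closest guide. For compound 4 a step within the scatter is expected, a 1.3-fold higher number from compound 3 to compound 4 (0.12 log units; within the scatter). Compound 4 is therefore estimated at 12000 nM, between 4000 nM and 40000 nM.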

Compound 4, solubility: 10900 nM
Compound 4: the middle estimate sits 1.1-fold (0.04 log units) above what was measured; low and high end bracket the measured number.
By their numbers in this assay, from the lowest: compounds 3 and 4 (each within the scatter of the next); then compound 1. At a limit, below all of these: compound 2.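

In this assay, 4-hydroxyphenyl brings a hydrogen-bond donor that thiophen-3-yl lacks, yet the step between the two stays within the scatter: a 1.2-fold higher number from compound 3 to compound 4 (0.08 log units; within the scatter). Measured against bromo, the drop seen with thiophen-3-yl recurs with a six-membered aromatic ring of carbon only carrying that donor, an 8.2-fold lower number from compound 1 to compound 4 (0.91 log units; beyond the scatter), so at this carbon on the five-membered aromatic ring both of these aryl groups sit well under bromo. The exchange for 3-chlorophenyl, an at least 2.1-fold higher number from compound 2 to compound 4 (0.33 log units; beyond the scatter), is the first aryl-for-aryl step at this carbon beyond the scatter, though the value of compound 2 is a limit of the assay: the limit of < 5000 nM in this assay, at which 1 of the 4 values shown sits.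

From the compounds shown here alone, what an amine or a carboxylic acid on the aryl group would do at this carbon stays open, as does whether any aryl group here can come back to the level of compound 1 at 89300 nM. The compounds shown vary only this one carbon, so whether these steps keep their size with a change elsewhere on the shared core also remains unknown.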